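Piperazine nitrogen substituent: cycloheptyl in place of pyridin-4-yl

A few compounds are considered here, and "the series" means these few. Any claim that something is new, unique, unknown or untested is made for them only; others in the source may bear on it.

The series shares one core, seen in compound 1 `Nc1scc(CN2CCN(c3cc(Cl)cc(Cl)c3)CC2)c1C(=O)c1ccc(Cl)cc1` and compound 2 `Nc1scc(CN2CCN(c3ccncc3)CC2)c1C(=O)c1ccc(Cl)cc1`, and differs only in the group on the amine nitrogen in the ring. In a functional assay on CHO cells with adenosine receptor A1 (Homo sapiens) as the target, read by cAMP accumulation and immunoassay, with a stated time of 6 min, tested at 10 uM (on this read-out lower numbers stand for a stronger effect and higher numbers for a weaker effect at the one concentration tested), compound 1 gives -74%, whereas compound 2 gives -15%. Going by the values given here, compound 2 thus stands highest of the two numbers measured so far, with compound 1 as its only neighbour; the one measured step, a number 59 percentage points higher from compound 1 to compound 2 (beyond the scatter), shows that the group at this nitrogen sets the read-out strongly.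

Compound 3 `Nc1scc(CN2CCN(C3CCCCCC3)CC2)c1C(=O)c1ccc(Cl)cc1` is not yet measured. Its difference from compound 2: cycloheptyl in place of pyridin-4-yl on an amine nitrogen in a ring. Among the compounds with values here, no measured step covers an exchange of an aromatic ring for a seven-membered non-aromatic ring at this nitrogen; the step from compound 1 to compound 2 is the only guide, and it concerns two aromatic groups. It shows only that large moves in either direction occur here. The expectation for compound 3 is therefore broad: a partial return toward the number of compound 1 is plausible but not secured, so the estimated step is a number 25 percentage points lower from compound 2 to compound 3 (beyond the scatter). The estimate for compound 3 is -40%, expected to lie between -80% and 5%.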

Compound 3, a percentage reported as activity, at one concentration (the size of the read-out at that concentration, not a potency): -25%
For compound 3 the middle estimate is 15 percentage points below the measured one, within the range that was stated.
By their numbers in this assay, from the lowest: compound 1; then compounds 3 and 2 (each within the scatter of the next).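

Exchanging a six-membered aromatic ring with one ring nitrogen for a seven-membered non-aromatic ring of carbon only at this piperazine nitrogen leaves the read-out within the usual variation: in this assay, the step is a number 10 percentage points lower from compound 2 to compound 3 (within the scatter), so pyridin-4-yl and cycloheptyl cannot be told apart here. The large change at this position therefore does not track the difference between an aromatic and a non-aromatic ring, since 3,5-dichlorophenyl also stands well apart from cycloheptyl, with a number 49 percentage points higher from compound 1 to compound 3 (beyond the scatter), as it does from pyridin-4-yl. No measurement available for this series gives a reason for this separation of compound 1 from compound 2 and compound 3.

Open, going by these compounds, is whether the separation of compound 1 goes with its phenyl ring or with its two chlorine atoms, a question that an unsubstituted phenyl or a 3-chlorophenyl on the same nitrogen would address. Also open, on these data alone, is how far a smaller carbon ring such as cyclohexyl, or a benzyl group, would stay with compound 2 and compound 3 or move toward compound 1.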